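Amide-type nitrogen substituent swap in the catechol ether series

A few compounds are considered here, and "the series" means these few. Any claim that something is new, unique, unknown or untested is made for them only; others in the source may bear on it.

Compound 1 `COc1ccc(C(=O)Nc2c(C)cccc2Cl)cc1OC1CCCC1` is the reference point of the set. Within the data shown here, in an assay on isolated protein for inhibition of phosphodiesterase 4A (Sus scrofa) (a higher number here means a weaker inhibitor, a lower number a stronger inhibitor), compound 1 gives 100 nM, the only numerical value among the three measured compounds. Compound 2 `COc1ccc(C(=O)Nc2ccccc2Cl)cc1OC(=O)C1CCCC1` returns only a limit, > 1000000 nM, in this assay. Compound 3 `COc1ccc(C(=O)Oc2c(Cl)cccc2Cl)cc1OC1CCCC1` likewise returns only a limit, > 1000000 nM, in this assay. Among the measured compounds shown here, two of the three results therefore sit at the limit of > 1000000 nM in this assay, at which 2 of the 3 values shown sit, which leaves compound 1 alone as a measured anchor and gives no measured step between compounds that differ in one place.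

Compound 4 `COc1ccc(C(=O)Nc2c(C)nsc2Br)cc1OC1CCCC1` keeps the shared core of compound 1 and differs from it in one place: 5-bromo-3-methyl-1,2-thiazol-4-yl in place of 2-chloro-6-methylphenyl on an amide-type nitrogen. For the measured compounds named here, no measured pair shows what such an exchange on the amide-type nitrogen does in this assay, so the expectation rests on the structural change alone. The group that enters is of similar size to the group that leaves, and the rest of compound 1 is retained. A modest step from compound 1 to compound 4, a 2.0-fold higher number from compound 1 to compound 4 (0.30 log units; within the scatter), toward somewhat weaker inhibition is expected, though a result within the scatter would not surprise. Compound 4 is estimated at 200 nM in this assay, with a range from 40 nM to 1000 nM.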

Compound 4, half-maximal inhibitory concentration: 500 nM
For compound 4 the middle estimate is 2.5-fold (0.40 log units) below the measured one; low and high end bracket the measured number.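

In this assay, among these compounds, placing 5-bromo-3-methyl-1,2-thiazol-4-yl in place of 2-chloro-6-methylphenyl on the amide-type nitrogen gives a 5.0-fold higher number from compound 1 to compound 4 (0.70 log units; beyond the scatter), the first measured step at this position, and it lies beyond the scatter. The position therefore accepts a five-membered aromatic ring with 2 hetero atoms in place of a six-membered aromatic ring of carbon only, with compound 4 still giving a numerical value of 500 nM rather than a limit. The exchange alters the ring, the halogen and the hydrogen-bond acceptor count in a single step, so this pair cannot show which of these changes carries the shift.

Among the compounds shown here, no step involving compound 2 or compound 3 can be read, since only compound 1 and compound 4 give numbers and the other results are limits: the limit of > 1000000 nM in this assay, at which 2 of the 4 values shown sit. What an unsubstituted phenyl, a pyridine ring or a 2-chloro-6-methylpyridin-3-yl group on the amide-type nitrogen would do in this assay stays open, as does whether chlorine in place of the bromine of compound 4 would move the value.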